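This account rests on a few compounds, and the source may have more. Where it says the series, first, only, none or still open, it means among the compounds named here.

Measured in a functional assay on DU-145 cells (Homo sapiens) for inhibition, read by trypan blue exclusion, with a stated time of 72 h; on this read-out lower numbers stand for stronger inhibition and higher numbers for weaker inhibition:
- compound 1 `Cn1c(=O)c(S(=O)(=O)c2ccccc2)cc2cnc(Nc3ccc4ncccc4c3)nc21`: 50000 nM
- compound 2 `Cn1c(=O)c(S(=O)(=O)Cc2ccc(F)cc2)cc2cnc(Nc3ccc4[nH]ccc4c3)nc21`: 30000 nM
- compound 3 `Cc1ccc(S(=O)(=O)c2cc3cnc(Nc4cnc5c(c4)CC(=O)N5)nc3n(C)c2=O)cc1`: 15000 nM

In this assay, compound 2 stands at 30000 nM. That value lies within the scatter of both other measurements, so this small set gives compound 2 no clear rank against either neighbour.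

Compound 4 `Cn1c(=O)c(S(=O)(=O)c2ccc(O)cc2)cc2cnc(Nc3ccc4[nH]ccc4c3)nc21` keeps the rest of compound 2 and carries 4-hydroxyphenyl in place of 4-fluorobenzyl on a sulfonyl sulfur. Going by the values given here, no measured pair isolates this change, so the data offer no direct guide to it. The best available support is indirect: compound 1 at 50000 nM and compound 3 at 15000 nM each differ from compound 2 in more than one place, yet each remains within the scatter of it.

A small move toward a lower number is therefore expected, with the estimated 1.7-fold lower number from compound 2 to compound 4 (0.22 log units; within the scatter) not clearly beyond the scatter. The expected value for compound 4 is 18000 nM, with an estimated range of 5000 nM to 50000 nM.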

Compound 4, half-maximal inhibitory concentration: 250 nM
Estimate against measurement, compound 4: 72-fold (1.86 log units) above; the whole stated range lies above it.
By their numbers in this assay, from the lowest: compound 4; then compounds 3, 2 and 1 (each within the scatter of the next, the first and the last beyond it).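

In this assay, 4-hydroxyphenyl in place of 4-fluorobenzyl on the sulfonyl sulfur gives a 120-fold lower number from compound 2 to compound 4 (2.08 log units; beyond the scatter), a large step far beyond the scatter. It shows that the group on this sulfur can decide the read-out on the shared core, something compounds 1 and 3 could not show, as each differs from compound 2 in more than one place. Nothing available explains why this exchange has so large an effect.

The exchange alters the ring substituent and the attachment to the sulfur together, so the compounds shown do not tell which of the two carries the step; 4-fluorophenyl or 4-hydroxybenzyl on the same sulfur would separate them. On these data alone, whether 4-methoxyphenyl or 4-aminophenyl would match 4-hydroxyphenyl also stays open.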